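A few compounds are considered here, and "the series" means these few. Any claim that something is new, unique, unknown or untested is made for them only; others in the source may bear on it.

Measured so far:
compound 1, `O=c1c(C2N=C(c3ccccc3)SS2)coc2ccc(Cl)cc12` — 73%
compound 2, `O=c1c(C2N=C(c3ccccc3)SS2)coc2cc(Cl)c(Cl)cc12` — 52%

Compound 2 stands lowest of the two numbers in a functional assay on A549 cells (Homo sapiens) for inhibition, read by sulforhodamine B assay, with a stated time of 48 h, tested at 100 uM; on this read-out lower numbers stand for less inhibition of growth and higher numbers for more inhibition of growth at the one concentration tested; its nearest neighbour is compound 1, which lies higher by a step that is beyond the scatter.

Compound 3, `O=c1c(C2N=C(c3ccccc3)SS2)coc2cc(Cl)c(F)cc12`, is not yet measured. It differs from compound 2 by fluoro in place of chloro on an aromatic carbon.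

Going by the values given here, the only measured step, a number 21 percentage points lower from compound 1 to compound 2 (beyond the scatter), concerns the same position, where a chloro took the place of hydrogen and the number fell modestly. Compound 3 keeps a halogen at that carbon, so that step bears only loosely on the change from chloro to fluoro; nothing measured shows a direct exchange of one halogen for another. Therefore only a small step, within the scatter, is expected here, estimated as a number 6 percentage points higher from compound 2 to compound 3 (within the scatter).

Compound 3 is estimated at 58%, with a range from 40% to 76%.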

Compound 3, percent growth inhibition at one concentration: 57%
Compound 3: middle estimate off by 1 percentage points, on the high side; the range from low to high includes it.
By their numbers in this assay, from the lowest: compounds 2 and 3 (each within the scatter of the next); then compound 1.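

Working notes: in this assay, a number 5 percentage points higher from compound 2 to compound 3 (within the scatter), so this first direct exchange of one halogen for another, on the carbon ortho to a chloro group, does not separate fluoro from chloro. Set against a number 21 percentage points lower from compound 1 to compound 2 (beyond the scatter), which put a chloro on the same carbon, the fluoro analogue reads with the chloro one: compound 3 at 57% stays under compound 1 at 73% in the same read-out. No available data bear on why these two halogens read alike.

Going by these compounds, how a methoxy group or an amine on this carbon would read remains open. So does whether fluoro at this position would give the same reading without the ortho chloro group, and whether the pattern holds at concentrations other than the single one reported.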